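Cytotoxicity on Vero cells across three chalcone amides

The source may report more compounds than this note shows. Statements on the series, on what has been measured and on what is new or still open speak of the compounds shown alone.

Measured so far:
- compound 1 `COC(=O)c1cc(-c2cccc(NC(=O)c3ccc(/C=C/C(=O)c4ccccc4OC)cc3)c2)on1`: > 40 ug/mL
- compound 2 `COC(=O)c1cc(-c2cccc(NC(=O)c3ccc(/C=C/C(=O)c4ccccc4Br)cc3)c2)on1`: > 40 ug/mL
- compound 3 `COC(=O)c1cc(-c2cccc(NC(=O)c3ccc(/C=C/C(=O)c4ccc(Br)cc4)cc3)c2)on1`: > 20 ug/mL

In an ADME assay on Vero cells (Chlorocebus sabaeus) for cytotoxicity, read by MTT assay, with a stated time of 72 h (a higher number here means that more compound is tolerated, a lower number that less compound is tolerated), compound 1 gives > 40 ug/mL, a limit of the assay rather than a number. Compound 2 likewise gives > 40 ug/mL, again a limit. Compound 3 gives > 20 ug/mL, also a limit. Because of the limit of > 40 ug/mL in this assay, at which 2 of the 3 values shown sit, and the limit of > 20 ug/mL in this assay, at which 1 of the 3 values shown sits, none of the steps between these compounds can be read as a size: a step that the two limits leave unreadable from compound 2 to compound 1, a step that the two limits leave unreadable from compound 1 to compound 3 and a step that the two limits leave unreadable from compound 2 to compound 3 all stay unreadable.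

The change from compound 2 to compound 1 is methoxy in place of bromo on an aromatic carbon. The cores of compound 2 and compound 3 differ as 4-bromophenyl in place of 2-bromophenyl on a carbonyl carbon. Compound 4 `COC(=O)c1cc(-c2cccc(NC(=O)c3ccc(/C=C/C(=O)c4ccc(OC)cc4)cc3)c2)on1` has not yet been measured; it differs from compound 3 as methoxy in place of bromo on an aromatic carbon. This is the same kind of change as that from compound 2 to compound 1, not the same change: in compound 1 the methoxy sits ortho to a large group, in compound 4 it sits para to a large group.

Since both compound 1 and compound 2 sit at a limit, and compound 3 also sits at a limit, the expectation for compound 4 in this assay is only that it will again be well tolerated. The step expected from compound 3 to compound 4 is a step that the limit leaves unreadable from compound 3 to compound 4, resting on compound 1 reaching > 40 ug/mL after the same kind of change. Compound 4 is estimated to give 60 ug/mL, between 20 ug/mL and 200 ug/mL, most likely reported as a limit once more.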

Compound 4, half-maximal cytotoxic concentration: > 10 ug/mL
Compound 4 gave a limit, no number; the forecaster's own chance of this, stated with the estimate: 85%; the middle value does not contradict the limit.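

In this assay compound 4 gives > 10 ug/mL, which is a limit and not a number. No step between compound 4 and compound 1, compound 2 or compound 3 can be read as a size, because compound 4 stands at a limit: the limit of > 10 ug/mL in this assay, at which 1 of the 4 values shown sits.

The compounds shown leave open where each true cytotoxic concentration lies, and so whether methoxy in place of bromo changes tolerance.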